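The compounds below may be only part of what the source reports. "The series", "measured", "known", "first", "only" and "open" are said of these compounds alone.

Measured so far in a functional assay on HCT-116 cells (Homo sapiens) for inhibition, read by colorimetric assay, with a stated time of 3 days; on this read-out lower numbers stand for stronger inhibition and higher numbers for weaker inhibition:
compound 1 `COc1ccc(NC(=O)CCCCCCNC(=O)C(O)(O)C(F)(F)F)cc1` gives 4520 nM;
compound 2 `COc1ccc2sc(NC(=O)CCCCCCNC(=O)C(O)(O)C(F)(F)F)nc2c1` gives 2180 nM;
compound 3 `O=C(CCCCCCNC(=O)C(O)(O)C(F)(F)F)Nc1c(F)cc(F)cc1F` gives 22200 nM.

Among these three, compound 3 holds the highest number, which on this read-out means the weakest inhibition; compound 1 is the nearest to it, and compound 2 the furthest away, both gaps lying beyond the usual scatter. Going by the values given here, the one measured step that touches compound 3 directly is a 4.9-fold higher number from compound 1 to compound 3 (0.69 log units; beyond the scatter), where the only change was the aromatic group on the amide nitrogen.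

Compound 4 `O=C(CCCCCCNC(=O)C(O)(O)C(F)(F)F)Nc1ccc(F)cc1` differs from compound 3 in just that group: 4-fluorophenyl in place of 2,4,6-trifluorophenyl on an amide-type nitrogen. Two of the three fluorines leave and a single fluorine remains. Among the compounds with values here, no measured pair matches this exact exchange, so the expectation rests on the step from compound 1 to compound 3: a methoxy-bearing phenyl gave the lower number, the trifluorinated phenyl the higher one, and compound 4 sits somewhere between those two groups. A step of about a 3.0-fold lower number from compound 3 to compound 4 (0.47 log units; beyond the scatter) toward a lower number is therefore expected for compound 4, a partial reversal of the rise seen from compound 1 to compound 3. The estimate for compound 4 in this assay is 7500 nM, with a range from 3000 nM to 18000 nM.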

Compound 4, half-maximal inhibitory concentration: 7570 nM
Compound 4: the middle estimate sits 1.0-fold (0.00 log units) below what was measured; the range from low to high includes it.
By their numbers in this assay, from the lowest: compound 2; then compounds 1 and 4 (each within the scatter of the next); then compound 3.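

In this assay, putting 4-fluorophenyl in place of 2,4,6-trifluorophenyl on the amide-type nitrogen gives a 2.9-fold lower number from compound 3 to compound 4 (0.47 log units; beyond the scatter), so the weak result of compound 3 does not come from the mere presence of fluorine on this ring: the number of fluorines at this position changes the read-out. The comparison with the methoxy compound adds a second point, since fluoro in place of methoxy on an aromatic carbon gives a 1.7-fold higher number from compound 1 to compound 4 (0.22 log units; within the scatter), and this assay therefore does not separate these two groups at this position. No measurement is available here that would explain either step.

As far as these compounds go, whether the higher number requires all three fluorines remains open, as a 2,4-difluorophenyl group would be needed to test that, and so does how an amine or a carboxylic acid on the phenyl ring would compare with fluoro and methoxy. These compounds also all share one chain, so they leave open whether these ring changes would give similar steps with a longer chain.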